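The compounds below may be only part of what the source reports. "The series", "measured", "known", "first", "only" and "open" are said of these compounds alone.

Compound 3, `O=C(CSC(=S)N[C@H]1CCOC1=O)Nc1ccccc1`, stands at a limit rather than a number: in a functional assay on EC9706 cells (Homo sapiens) for cytotoxicity, read by MTT assay, with a stated time of 72 h (on this read-out lower numbers stand for stronger inhibition and higher numbers for weaker inhibition), compound 3 gives > 128000 nM. Compound 1, `O=C(CSC(=S)N[C@H]1CCOC1=O)Nc1ccccc1F`, sits at a limit too, since in this assay compound 1 gives > 128000 nM. Compound 2, `O=C(CSC(=S)N[C@H]1CCOC1=O)Nc1ccc(Br)cc1`, is the only one of the three with a measured number, as in this assay compound 2 gives 67400 nM. In short, (the limit of > 128000 nM in this assay, at which 2 of the 3 values shown sit).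

Compound 4, `COc1ccc(NC(=O)CSC(=S)N[C@H]2CCOC2=O)cc1`, differs from compound 3 by methoxy in place of hydrogen on an aromatic carbon. Among the measured compounds shown here, two measured steps touch this change. The first is an at least 1.8-fold higher number from compound 2 to compound 3 (0.27 log units; that floor lies within the scatter), a floor that sits within the scatter. The second is a step that the two limits leave unreadable from compound 1 to compound 3, which cannot be sized from two limits. Between the two other compounds, an at least 1.8-fold lower number from compound 1 to compound 2 (0.27 log units; that floor lies within the scatter) is again only a floor. Putting a methoxy where compound 3 carries hydrogen is thus supported only by the weak hint that compound 2, with bromo on the corresponding aromatic carbon, reached a number at all. He therefore expects a small step to a lower number in this assay for compound 4, or none beyond the scatter. Compound 4 is estimated at 100000 nM, with a range from 40000 nM to 250000 nM. That expectation corresponds to a step of an at least 1.2-fold lower number from compound 3 to compound 4 (0.10 log units; that floor lies within the scatter).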

Compound 4, half-maximal inhibitory concentration: > 128000 nM
Compound 4 was reported as a limit; the forecaster's own chance of this, stated with the estimate: 50%; at least 1.2-fold (0.10 log units) between middle value and limit.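

In this assay, methoxy on this aromatic carbon, para to a large group, does not bring compound 4 to a measured number, and its result is a limit. Among the compounds shown here, the only readable comparison for this change is with bromo on the same carbon, an at least 1.8-fold higher number from compound 2 to compound 4 (0.27 log units; that floor lies within the scatter), so the two groups are not separated beyond the scatter, and the steps between two limits cannot be read. Compound 2 therefore remains the only one of the four with a measured number, which shows that a group at this place does not by itself yield one: the limit of > 128000 nM in this assay, at which 3 of the 4 values shown sit.

The compounds shown leave open whether another group on this aromatic carbon, such as chloro, nitrile, trifluoromethyl or an amine, would give a measured number and how it would compare with bromo. They also leave open how far the compounds at the limit lie from a measurable number, and whether a longer chain on the amide-type nitrogen would change the picture.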